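This account rests on a few compounds, and the source may have more. Where it says the series, first, only, none or still open, it means among the compounds named here.

Compounds measured so far:
compound 1 `CC(=O)N(O)C(C)c1ccc2oc(-c3ccccc3)cc2c1` — 490 nM
compound 2 `COc1cccc(OC)c1C(=O)N(O)C(C)c1ccc2oc(-c3ccccc3)cc2c1` — 3000 nM

In an assay on RBL cells for inhibition of Polyunsaturated fatty acid 5-lipoxygenase (Rattus norvegicus) (on this read-out higher numbers stand for weaker inhibition and lower numbers for stronger inhibition), compound 2 has the highest of the two numbers, with compound 1 as its nearest neighbour. Among the measured compounds shown here, the only measured step that bears on this position is a 6.1-fold higher number from compound 1 to compound 2 (0.79 log units; beyond the scatter). Compound 3 `CC(c1ccc2oc(-c3ccccc3)cc2c1)N(O)C(=O)c1ccco1` carries a change at the same place: furan-2-yl in place of 2,6-dimethoxyphenyl on a carbonyl carbon. That replaces a large group with a smaller aromatic one, so the step from the small methyl of compound 1 is expected to be partly reversed. Compound 3 is therefore expected to give a somewhat lower number, a 2.5-fold lower number from compound 2 to compound 3 (0.40 log units; beyond the scatter), with an estimate of 1200 nM and a range from 400 nM to 3500 nM.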

Compound 3, half-maximal inhibitory concentration: 40 nM
The estimate for compound 3 lay 30-fold (1.48 log units) above the measured number, outside the stated range (below it).
By their numbers in this assay, from the lowest: compound 3; then compound 1; then compound 2.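

In this assay, furan-2-yl in place of 2,6-dimethoxyphenyl on a carbonyl carbon gives a 75-fold lower number from compound 2 to compound 3 (1.88 log units; beyond the scatter), and furan-2-yl in place of methyl gives a 12-fold lower number from compound 1 to compound 3 (1.09 log units; beyond the scatter). The number at this place therefore does not simply rise with the size of the group: furan-2-yl, intermediate in size among the three groups, gives the lowest number. Nothing measured here accounts for this result. The compounds shown leave open whether an unsubstituted phenyl or a thiophen-2-yl would match furan-2-yl, and so whether the aromatic ring alone or its oxygen matters.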